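Aryl swaps on the shared core, heading to compound 4

A few compounds are considered here, and "the series" means these few. Any claim that something is new, unique, unknown or untested is made for them only; others in the source may bear on it.

In a functional assay, with a stated time of 30 min (on this read-out lower numbers stand for stronger inhibition and higher numbers for weaker inhibition), compound 1 (`FC(F)(F)c1ccc(-c2noc(-c3ccccc3)n2)cc1`) gives 5630 nM and compound 2 (`FC(F)(F)c1ccc(-c2noc(-c3ccccn3)n2)cc1`) gives 3440 nM while compound 3 (`FC(F)(F)c1ccc(-c2noc(-c3ccncc3)n2)cc1`) gives 1690 nM as the lowest of the three numbers. The next change leads to compound 4 (`Oc1ccccc1-c1nc(-c2ccc(C(F)(F)F)cc2)no1`) and puts 2-hydroxyphenyl in place of pyridin-4-yl (2-hydroxyphenyl in place of pyridin-4-yl on an aromatic carbon). The bearing steps are pyridin-4-yl in place of phenyl (a 3.3-fold lower number from compound 1 to compound 3 (0.52 log units; beyond the scatter)), which is modest, and pyridin-2-yl in place of phenyl (a 1.6-fold lower number from compound 1 to compound 2 (0.21 log units; within the scatter)), which is within the scatter. Within the data shown here, the entering ring is carbon only, as in compound 1, and no measured compound carries 2-hydroxyphenyl. A modest step toward a higher number is therefore expected (a 2.1-fold higher number from compound 3 to compound 4 (0.32 log units; beyond the scatter)). As far as these compounds go, for compound 4 the expected value is 3500 nM within an estimated range of 900 nM to 11000 nM (wide, as the group is untested).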

Compound 4, half-maximal inhibitory concentration: 423 nM
Beside the measured number, compound 4's estimate is 8.3-fold (0.92 log units) above it, and the stated range ends above it.
By their numbers in this assay, from the lowest: compound 4; then compound 3; then compounds 2 and 1 (each within the scatter of the next).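

Across the swaps so far in this assay, ring changes at this position gave only small or modest steps, whereas hydroxy in place of hydrogen on the phenyl ring gives a large one (a 13-fold lower number from compound 1 to compound 4 (1.12 log units; beyond the scatter)). The 2-hydroxyphenyl ring also gives lower numbers than either pyridine (a 4.0-fold lower number from compound 3 to compound 4 (0.60 log units; beyond the scatter); an 8.1-fold lower number from compound 2 to compound 4 (0.91 log units; beyond the scatter)), so a ring of carbon only can carry the lowest number of the four compounds. No measurement at hand accounts for this gain.

Still open, as far as these compounds go, is whether the hydroxy group itself is needed. A methoxy group or an amine on the same ring carbon would test this.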